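The source may hold more compounds than are shown below. What is called first, only, known or untested is meant among the compounds shown, and "the series" means these compounds.

Measured compounds in a functional assay on L6 cells (Rattus norvegicus) for inhibition; on this read-out higher numbers stand for weaker inhibition and lower numbers for stronger inhibition:
- compound 1 `CC(C)c1c(C(=O)N(C)Cc2ccccc2)nn(-c2ccc(F)cc2)c1CC[C@@H](O)C[C@@H](O)CC(=O)O`: 2870 nM
- compound 2 `CC(C)c1c(C(=O)N2CCC[C@H](c3ccccc3)C2)nn(-c2ccc(F)cc2)c1CC[C@@H](O)C[C@@H](O)CC(=O)O`: 310 nM
- compound 3 `CC(C)c1c(C(=O)N2CCCCC2)nn(-c2ccc(F)cc2)c1OC[C@@H](O)C[C@@H](O)CC(=O)O`: 32200 nM

Compound 3 gives the highest number of the three, so it is the weakest inhibitor of the set; compound 1 lies well below it and compound 2 lies furthest below it, both gaps beyond the scatter. Compound 4 `CC(C)c1c(C(=O)N(C)Cc2cccc(Cl)c2)nn(-c2ccc(F)cc2)c1OC[C@@H](O)C[C@@H](O)CC(=O)O` differs from compound 3 in one place: (3-chlorobenzyl)(methyl)amino in place of piperidin-1-yl on a carbonyl carbon. Among the compounds with values here, the only measured step that touches the amide substituent is a 9.3-fold lower number from compound 1 to compound 2 (0.97 log units; beyond the scatter), which shows that a ring amine carrying a phenyl group gave a clearly lower number than the open benzyl(methyl)amino. The present change runs the other way, opening a ring to a (3-chlorobenzyl)(methyl)amino, but compound 3 carries a plain piperidin-1-yl without any aromatic ring, so the comparison is indirect. A modest move toward a lower number is expected, a 3.6-fold lower number from compound 3 to compound 4 (0.55 log units; beyond the scatter), with wide uncertainty. Compound 4 is therefore estimated at 9000 nM in this assay, within 2500 nM to 35000 nM.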

Compound 4, half-maximal inhibitory concentration: 2120 nM
Compound 4: middle estimate off by 4.2-fold (0.63 log units), on the high side, outside the stated range (below it).
By their numbers in this assay, from the lowest: compound 2; then compounds 4 and 1 (each within the scatter of the next); then compound 3.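

In this assay, the amide substituent on the carbonyl carbon also has a large influence when the core carries the oxygen-linked side chain of compound 3 and compound 4, with a 15-fold lower number from compound 3 to compound 4 (1.18 log units; beyond the scatter). The earlier step, a 9.3-fold lower number from compound 1 to compound 2 (0.97 log units; beyond the scatter), favoured a ring amine carrying a phenyl group over an open benzyl(methyl)amino, whereas here an open amine carrying an aromatic ring gives the lower number against a plain piperidine ring, so having a ring at the amide nitrogen does not by itself give the lower number. Nothing available explains the size of this step.

The change from compound 3 to compound 4 adds the chlorine, the aromatic ring and the open amine together, so their separate contributions remain unresolved. A simple dimethylamino on the same core, or a benzyl(methyl)amino without the chlorine, would help to separate them.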